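Phenyl substituent series: removing the benzyl from compound 3

A few compounds are considered here, and "the series" means these few. Any claim that something is new, unique, unknown or untested is made for them only; others in the source may bear on it.

Compound 3 `O=C1NCCN(c2cccc(OCc3ccccc3)c2)N1` gives the lowest number of the three in an assay on RBL-1 cells for inhibition of Polyunsaturated fatty acid 5-lipoxygenase (Rattus norvegicus) (on this read-out higher numbers stand for weaker inhibition and lower numbers for stronger inhibition), at 1100 nM; compound 2 `O=C1NCCN(c2cccc(Cl)c2)N1` gives 5300 nM and compound 1 `CCc1cccc(N2CCNC(=O)N2)c1` gives 13000 nM. Among the measured compounds shown here, the only single-point step measured so far, a 2.5-fold lower number from compound 1 to compound 2 (0.39 log units; beyond the scatter), replaces one ring substituent with another and does not touch the oxygen. Compound 4 `O=C1NCCN(c2cccc(O)c2)N1` differs from compound 3 by hydrogen in place of benzyl on an oxygen on an aromatic ring. For the measured compounds named here, no measured step covers this change, so the expectation rests only on the spread among compound 1, compound 2 and compound 3. Compound 4 is expected to give a higher number, an estimated 4.5-fold higher number from compound 3 to compound 4 (0.66 log units; beyond the scatter). For compound 4 the estimate in this assay is 5000 nM, expected to fall between 1500 nM and 20000 nM.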

Compound 4, half-maximal inhibitory concentration: 32000 nM
The estimate for compound 4 lay 6.4-fold (0.81 log units) below the measured number; measured number outside the range, above it.
By their numbers in this assay, from the lowest: compound 3; then compound 2; then compound 1; then compound 4.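

In this assay, among the compounds shown here, hydrogen in place of benzyl on the oxygen gives a 29-fold higher number from compound 3 to compound 4 (1.46 log units; beyond the scatter) and is the largest step so far, so the benzyl accounts for much of the standing of compound 3. Hydroxy also trails the other ring substituents, with a 6.0-fold higher number from compound 2 to compound 4 (0.78 log units; beyond the scatter) for the change from chloro and a 2.5-fold higher number from compound 1 to compound 4 (0.39 log units; beyond the scatter) for the change from ethyl. Nothing available here accounts for these differences.

The compounds shown leave open whether the aromatic ring of the benzyl matters or any carbon group on the oxygen would serve. A methyl ether or a longer alkyl chain on the oxygen would separate these two readings.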